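A few compounds are considered here, and "the series" means these few. Any claim that something is new, unique, unknown or untested is made for them only; others in the source may bear on it.

In a toxicity assay on cells (Macrophage, Mus musculus, strain BALB/c) for cytotoxicity, read by MTT assay (on this read-out lower numbers stand for stronger inhibition and higher numbers for weaker inhibition), compound 1 (`C=CCOc1cc(/C=C/C(=O)c2c(O)cc(O)cc2OC)cc(OCC=C)c1Br`) gives 11500 nM and compound 2 (`COc1cc(O)cc(O)c1C(=O)/C=C/c1ccco1`) gives 384000 nM as the higher of the two numbers, a gap beyond the scatter. Compound 3 (`COc1cc(O)cc(O)c1C(=O)/C=C/c1ccc(C)cc1`) differs from compound 2 by 4-methylphenyl in place of furan-2-yl on a double-bonded chain carbon bound to a double-bonded chain carbon on a double-bonded chain carbon bound to a double-bonded chain carbon. Within the data shown here, no measured pair isolates this change, so the only guide is compound 1 at 11500 nM on the shared core, which differs in several places. The expected step is a 5.5-fold lower number from compound 2 to compound 3 (0.74 log units; beyond the scatter) in this assay and points to a lower number, meaning stronger inhibition. The value estimated for compound 3 is 70000 nM (18000 nM to 280000 nM).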

Compound 3, half-maximal inhibitory concentration: 16500 nM
For compound 3 the middle estimate is 4.2-fold (0.63 log units) above the measured one; the whole stated range lies above it.
By their numbers in this assay, from the lowest: compounds 1 and 3 (each within the scatter of the next); then compound 2.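

In this assay, among these compounds, putting 4-methylphenyl in place of furan-2-yl on a double-bonded chain carbon bound to a double-bonded chain carbon gives a 23-fold lower number from compound 2 to compound 3 (1.37 log units; beyond the scatter) and is the first change here that can be read alone. It shows that this one position, with the rest of the shared core held constant, can move the read-out by a large step. No measurement shown accounts for the step. The compounds shown leave open whether the ring or its methyl carries the change. An unsubstituted phenyl or a 4-methoxyphenyl at this place would separate the two.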